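Chloro for fluoro on the benzyl ring of compound 3

The compounds below may be only part of what the source reports. "The series", "measured", "known", "first", "only" and "open" are said of these compounds alone.

Compound 1, `O=c1c2cnn(-c3ccc(F)cc3)c2ncn1CC1(O)CCN(Cc2ccc(F)cc2Cl)CC1`, gives 1600 nM in an assay on Sf21 cells for inhibition of ubiquitin carboxyl-terminal hydrolase 7 (Homo sapiens), read by spectrophotometry, with stated times of 30 min and 2 h; on this read-out lower numbers stand for stronger inhibition and higher numbers for weaker inhibition.
Compound 2, `O=c1c2cnn(-c3ccc(F)cc3)c2ncn1CC1(O)CCN(Cc2ccc(Cl)cc2Cl)CC1`, gives 3300 nM in this assay.
Compound 3, `COC(=O)c1ccc(CN2CCC(O)(Cn3cnc4c(cnn4-c4ccc(F)cc4)c3=O)CC2)c(F)c1`, gives 800 nM in this assay.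

Compound 4, `COC(=O)c1ccc(CN2CCC(O)(Cn3cnc4c(cnn4-c4ccc(F)cc4)c3=O)CC2)c(Cl)c1`, has not been measured. It differs from compound 3 by chloro in place of fluoro on an aromatic carbon. The same kind of change separates compound 1 from compound 2, (chloro in place of fluoro on an aromatic carbon), where it produced a 2.1-fold higher number from compound 1 to compound 2 (0.31 log units; beyond the scatter). The surroundings differ: in compound 1 the site is meta to a chloro group and para to a large group, whereas in compound 3 it is ortho to a large group and meta to a methoxycarbonyl group. The two cores differ by 2-fluoro-4-(methoxycarbonyl)phenyl in place of 2-chloro-4-fluorophenyl on a saturated chain carbon bound to an amine nitrogen in a ring, which gave a 2.0-fold lower number from compound 1 to compound 3 (0.30 log units; within the scatter). Within the data shown here, compound 4 is expected to show a step like the earlier one, a 1.8-fold higher number from compound 3 to compound 4 (0.24 log units; within the scatter), because a 2.1-fold higher number from compound 1 to compound 2 (0.31 log units; beyond the scatter) is the only guide for this change. For compound 4 the estimate is therefore 1400 nM, with a range from 500 nM to 4000 nM.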

Compound 4, half-maximal inhibitory concentration: 800 nM
The estimate for compound 4 lay 1.8-fold (0.24 log units) above the measured number, and the stated range covers the measured number.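

In this assay, chloro in place of fluoro on the core of compound 3 gives no change at the digits printed from compound 3 to compound 4 (within the scatter), and the two steps for this change cannot be told apart: the same change on two cores in this assay, a 2.1-fold higher number (0.31 log units; beyond the scatter) from compound 1 to compound 2 and no change at the digits printed (within the scatter) from compound 3 to compound 4, 2.1-fold (0.31 log units) apart, within the scatter of two such steps. The change therefore carries between these two cores without a detectable difference, but a single pair on each core does not show that the step has the same size on both. With chloro held in place, methoxycarbonyl in place of chloro gives a 4.1-fold lower number from compound 2 to compound 4 (0.62 log units; beyond the scatter), while methoxycarbonyl in place of fluoro gives a 2.0-fold lower number from compound 1 to compound 4 (0.30 log units; within the scatter).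

The compounds shown leave open how the chloro-for-fluoro step behaves when a carboxylic acid or an amide stands in place of methoxycarbonyl. They also leave open what a bromo or methyl group would do in place of the halogen.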